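Chloro Added to the Fluorophenyl Hydrazone of Compound 2

The source may hold more compounds than are shown below. What is called first, only, known or untested is meant among the compounds shown, and "the series" means these compounds.

Compound 1 `CN(C)CCn1cnnc1-c1cc(Oc2ccc(NC(=O)N/N=C/c3ccc(O)c(Br)c3)cc2F)ccn1`: 12400 nM
Compound 2 `CN(C)CCn1cnnc1-c1cc(Oc2ccc(NC(=O)N/N=C/c3ccc(F)cc3)cc2F)ccn1`: 2310 nM

In a functional assay on U-87MG ATCC cells (Homo sapiens) for cytotoxicity, read by MTT assay, with a stated time of 72 h (on this read-out lower numbers stand for stronger inhibition and higher numbers for weaker inhibition), compound 1 gives 12400 nM. Going by the values given here, compound 2 carries a 4-fluorophenyl in place of the 3-bromo-4-hydroxyphenyl on the carbon with a double bond to nitrogen, and in this assay compound 2 gives 2310 nM, the lower of the two numbers; the step of a 5.4-fold lower number from compound 1 to compound 2 (0.73 log units; beyond the scatter) separates it from its only neighbour, compound 1.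

Compound 3 `CN(C)CCn1cnnc1-c1cc(Oc2ccc(NC(=O)N/N=C/c3ccc(F)cc3Cl)cc2F)ccn1` keeps the whole of compound 2 apart from one change: chloro in place of hydrogen on an aromatic carbon. Among the compounds with values here, the only measured step, the one from compound 1 to compound 2, exchanged the whole aryl group and so bears on this change only loosely; no measured pair shows what a chloro added to this ring does on its own. Compound 3 is therefore expected to stay close to compound 2, with a step of a 1.3-fold lower number from compound 2 to compound 3 (0.11 log units; within the scatter) that may well fall within the scatter. For compound 3 the estimate in this assay is 1800 nM, with a range from 600 nM to 5500 nM.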

Compound 3, half-maximal inhibitory concentration: 1210 nM
Beside the measured number, compound 3's estimate is 1.5-fold (0.17 log units) above it, within the range that was stated.
By their numbers in this assay, from the lowest: compounds 3 and 2 (each within the scatter of the next); then compound 1.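

In this assay, chloro in place of hydrogen on the aromatic carbon ortho to a large group and meta to a fluoro group gives a 1.9-fold lower number from compound 2 to compound 3 (0.28 log units; within the scatter), so the first chlorine seen on this ring leaves the number within the scatter of compound 2. Going by these compounds alone, what the earlier compounds could not show separately now stands on its own: this carbon of the 4-fluorophenyl accepts a chloro with no change that can be told from the scatter. The exchange of the whole aryl group, 2-chloro-4-fluorophenyl in place of 3-bromo-4-hydroxyphenyl, gives a 10-fold lower number from compound 1 to compound 3 (1.01 log units; beyond the scatter), a large step, and it keeps the separation from compound 1 already seen with compound 2, while nothing shown here gives a measured reason for either result.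

The compounds shown leave open how much of the separation from compound 1 belongs to the bromo and how much to the hydroxy, as the two groups leave together in every step. Going by these compounds, it also stays open whether a larger group on this same aromatic carbon, such as a methoxy or a trifluoromethyl, would stay as close to compound 2 as the chloro does.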